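Swapping hydroxyamino for hydroxy on two related cores

The compounds below may be only part of what the source reports. "The series", "measured", "known", "first", "only" and "open" are said of these compounds alone.

Compound 1 `O=C(NO)[C@H]1CC[C@]2(CC1)OO[C@]1(O2)C2CC3CC(C2)CC1C3` carries a hydroxyamino group on a carbonyl carbon, and compound 2 `O=C(O)[C@H]1CC[C@]2(CC1)OO[C@]1(O2)C2CC3CC(C2)CC1C3` is its counterpart in which that group is replaced, a change described as hydroxy in place of hydroxyamino on a carbonyl carbon. In a functional assay on SMMC-7721 cells (Homo sapiens) for cytotoxicity, read by MTT assay, with a stated time of 48 h (a higher number here means a weaker inhibitor, a lower number a stronger inhibitor), compound 1 gives only a limit, > 50000 nM. In this assay compound 2 also gives only a limit, > 100000 nM. The size of the step that the two limits leave unreadable from compound 1 to compound 2 cannot be read, because the limit of > 100000 nM in this assay, at which 1 of the 3 values shown sits, and the limit of > 50000 nM in this assay, at which 2 of the 3 values shown sit, are limits rather than numbers.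

Compound 3 `O=C(NO)[C@H]1CC[C@@]2(CC1)OC[C@]1(OO2)C2CC3CC(C2)CC1C3` is built on a different core; the difference between the two cores is not broken down here. In this assay compound 3 gives only a limit, > 50000 nM. Compound 4 `O=C(O)[C@H]1CC[C@@]2(CC1)OC[C@]1(OO2)C2CC3CC(C2)CC1C3`, not yet measured, differs from compound 3 by hydroxy in place of hydroxyamino on a carbonyl carbon, the same change seen between compound 1 and compound 2, at the same kind of place.

With compound 3 sitting at a limit, > 50000 nM, and the earlier step unreadable, compound 4 is expected to stay weak. The expected step is a step that the limit leaves unreadable from compound 3 to compound 4. Compound 4 is estimated at 100000 nM, within a range from 50000 nM to 300000 nM, and most likely reported again only as a limit.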

Compound 4, half-maximal inhibitory concentration: > 100000 nM
Compound 4: only a limit was reported (the forecaster's own chance of this, stated with the estimate: 85%); the middle value sits exactly at the limit.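

No step can be read from compound 3 to compound 4: in this assay each of the two gives only a limit, not a number. The compounds shown leave open how strong any of compound 1, compound 2, compound 3 or compound 4 really is, and whether swapping hydroxyamino for hydroxy changes that strength at all.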